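Swapping chloro for fluoro on an inactive aryl ester

The source may report more compounds than this note shows. Statements on the series, on what has been measured and on what is new or still open speak of the compounds shown alone.

Compound 1 `C#CCOC(=O)/C(C)=C/CC/C(C)=C/CC/C(C)=C/CC[C@@H]1[C@@]2(C)CCC(=O)C(C)(C)[C@H]2CC[C@@]1(C)O`: 45100 nM
Compound 2 `C/C(=C\CC/C(C)=C/CC[C@@H]1[C@@]2(C)CCC(=O)C(C)(C)[C@H]2CC[C@@]1(C)O)CC/C=C(\C)C(=O)OCc1cn(-c2ccc(Br)cc2)nn1`: > 150000 nM (a limit)
Compound 3 `C/C(=C\CC/C(C)=C/CC[C@@H]1[C@@]2(C)CCC(=O)C(C)(C)[C@H]2CC[C@@]1(C)O)CC/C=C(\C)C(=O)OCc1cn(-c2ccccc2Cl)nn1`: > 150000 nM (a limit)

In a functional assay on A549 cells (Homo sapiens) for antiproliferative activity, read by MTT assay, with a stated time of 48 h (on this read-out lower numbers stand for stronger inhibition and higher numbers for weaker inhibition), compound 3 has no number, only a limit, > 150000 nM. Compound 2 shares it, so the series sits at the limit of > 150000 nM in this assay, at which 2 of the 3 values shown sit.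

Compound 4 `C/C(=C\CC/C(C)=C/CC[C@@H]1[C@@]2(C)CCC(=O)C(C)(C)[C@H]2CC[C@@]1(C)O)CC/C=C(\C)C(=O)OCc1cn(-c2ccccc2F)nn1` differs from compound 3 by fluoro in place of chloro on an aromatic carbon, with fluoro in place of chloro on an aromatic carbon, ortho to a large group. For the measured compounds named here, no measured step makes this exchange. The nearest evidence is an at least 3.3-fold higher number from compound 1 to compound 3 (0.52 log units; beyond the scatter) and an at least 3.3-fold higher number from compound 1 to compound 2 (0.52 log units; beyond the scatter), both of which install an aryl triazolyl group in place of ethynyl. Going by the values given here, the one step that alters the aryl group, a step that the two limits leave unreadable from compound 2 to compound 3, cannot be sized.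

Compound 4 keeps the 1-(2-fluorophenyl)-1H-1,2,3-triazol-4-yl group, so it is expected to stay near the limit of compound 3, with no change beyond the scatter. The expected step is a number no higher from compound 3 to compound 4 (the limit leaves the size open).

For compound 4, the estimated value is 150000 nM, with an expected range of 70000 nM to 300000 nM.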

Compound 4, half-maximal inhibitory concentration: > 150000 nM
Compound 4 was reported as a limit; the forecaster's own chance of this, stated with the estimate: 75%; the middle value sits exactly at the limit.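

In this assay compound 4 gives only a limit, > 150000 nM, so fluoro in place of chloro on this aromatic carbon, ortho to a large group, does not bring the compound into a measurable range. The 1-(2-fluorophenyl)-1H-1,2,3-triazol-4-yl group in place of ethynyl gives an at least 3.3-fold higher number from compound 1 to compound 4 (0.52 log units; beyond the scatter), making this the third aryl triazolyl group with this outcome. The steps among the three aryl triazolyl compounds cannot be read, and the series now gathers at one limit: the limit of > 150000 nM in this assay, at which 3 of the 4 values shown sit.

Any real differences among these aryl groups therefore remain hidden. Going by these compounds, it also remains open whether an amine or a carboxylic acid on the phenyl ring, or a simple alkyl group on the triazole in place of the aryl group, would yield a measurable value.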